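Adding a Nitro Group to Two Related Cores

The source may report more compounds than this note shows. Statements on the series, on what has been measured and on what is new or still open speak of the compounds shown alone.

Compound 1 `CCN1C(=O)N(CC)C2C1N=C(SC)N2/N=C/C=C/c1ccccc1` is tested in a functional assay on RD cells (Homo sapiens) for inhibition, read by MTT assay, with a stated time of 72 h (a lower number here means a stronger inhibitor, a higher number a weaker inhibitor), where compound 1 gives 24000 nM. Compound 2 `CCN1C(=O)N(CC)C2C1N=C(SC)N2/N=C/C=C/c1ccccc1[N+](=O)[O-]` carries nitro in place of hydrogen on an aromatic carbon and gives 41900 nM in this assay, a step of a 1.7-fold higher number from compound 1 to compound 2 (0.24 log units; within the scatter). Compound 3 `CCN1C(=O)N(CC)C2C1NC(=O)N2/N=C/C=C/c1ccccc1` rests on a different core, and the difference between the two cores is not broken down here; in this assay compound 3 gives 2020 nM, which stands clearly below compound 1 and compound 2. Compound 4 `CCN1C(=O)N(CC)C2C1NC(=O)N2/N=C/C=C/c1ccccc1[N+](=O)[O-]` bears nitro in place of hydrogen on an aromatic carbon, the same change that separates compound 1 from compound 2. The expected step from compound 3 to compound 4 in this assay is a 1.7-fold higher number from compound 3 to compound 4 (0.23 log units; within the scatter), resting on the step of a 1.7-fold higher number from compound 1 to compound 2 (0.24 log units; within the scatter) seen on the other core. Compound 4 is therefore expected to give 3400 nM, with a likely range from 1500 nM to 8000 nM.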

Compound 4, half-maximal inhibitory concentration: 1930 nM
The estimate for compound 4 lay 1.8-fold (0.25 log units) above the measured number; low and high end bracket the measured number.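

In this assay, on the second core, nitro in place of hydrogen on an aromatic carbon gives a 1.0-fold lower number from compound 3 to compound 4 (0.02 log units; within the scatter). Set beside the earlier step, the change carries from one core to the other with no difference that can be told apart: the same change on two cores in this assay, a 1.7-fold higher number (0.24 log units; within the scatter) from compound 1 to compound 2 and a 1.0-fold lower number (0.02 log units; within the scatter) from compound 3 to compound 4, 1.8-fold (0.26 log units) apart, within the scatter of two such steps This rests on a single pair of compounds per core and one place on the ring, so it does not show that the change would carry over in the same way to further cores.

As far as these compounds go, whether an amine or a carboxylic acid in that place would also carry across the two cores stays open. The compounds shown also leave open which part of the difference between the two cores sets their numbers apart.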